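The source may hold more compounds than are shown below. What is called first, only, known or untested is meant among the compounds shown, and "the series" means these compounds.

Measured so far in an ADME assay on HepG2 cells (Homo sapiens) for cytotoxicity, read by luminescence, CellTiter-Glo and ATP content, with a stated time of 72 h; a lower number here means that less compound is needed, a higher number that more compound is needed for the effect:
compound 1 `CC(C)(C)c1ccc(Oc2ccc3c(NCCCNCc4ccco4)ccnc3c2)cc1` gives 3100 nM
compound 2 `COc1ccc(Oc2ccc3c(NCCCNCc4ccco4)ccnc3c2)cc1` gives 5300 nM
compound 3 `COc1cccc(CNCCCNc2ccnc3cc(Oc4cccc(N(C)C)c4)ccc23)c1O` gives 7300 nM

Compound 3 has the highest of the three numbers in this assay; compound 2 sits close to it, within the scatter, while compound 1 lies further off, beyond it. Compound 4 `CN(C)c1cccc(Oc2ccc3c(NCCCNCc4ccco4)ccnc3c2)c1` differs from compound 3 by furan-2-yl in place of 2-hydroxy-3-methoxyphenyl on a saturated chain carbon bound to an amine nitrogen. For the measured compounds named here, no measured step covers this change. Going by the values given here, the single measured step, a 1.7-fold higher number from compound 1 to compound 2 (0.23 log units; within the scatter), concerns a different place and stays within the scatter, and the whole series spans only a narrow band in this assay. No step beyond the scatter is therefore expected. Compound 4 is expected to come in at 5000 nM, with a range from 2500 nM to 10000 nM. This estimate means an expected step of a 1.5-fold lower number from compound 3 to compound 4 (0.16 log units; within the scatter).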

Compound 4, half-maximal effective concentration: 16000 nM
Compound 4: the middle estimate sits 3.2-fold (0.51 log units) below what was measured; the measured number lies above the stated range.
By their numbers in this assay, from the lowest: compounds 1, 2 and 3 (each within the scatter of the next, the first and the last beyond it); then compound 4.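

In this assay the saturated chain carbon bound to an amine nitrogen proves able to shift the number beyond the scatter, with furan-2-yl in place of 2-hydroxy-3-methoxyphenyl giving a 2.2-fold higher number from compound 3 to compound 4 (0.34 log units; beyond the scatter) at this place. With furan-2-yl held, 3-(dimethylamino)phenyl on the oxygen gives a 3.0-fold higher number from compound 2 to compound 4 (0.48 log units; beyond the scatter) against 4-methoxyphenyl and a 5.2-fold higher number from compound 1 to compound 4 (0.71 log units; beyond the scatter) against 4-(tert-butyl)phenyl on that oxygen. Nothing available speaks to the reason for these steps. Still open, going by these compounds, is how a plain phenyl or a carboxylic acid would read on that chain carbon.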